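Swapping tert-butyl for trifluoromethoxy on an inactive scaffold

The source may hold more compounds than are shown below. What is called first, only, known or untested is meant among the compounds shown, and "the series" means these compounds.

Of the compounds shown here, three have so far been tested in an assay on HEK293 cells for inhibition of transient receptor potential cation channel subfamily V member 1 (Homo sapiens), read by FLIPR, at pH 5.5; on this read-out higher numbers stand for weaker inhibition and lower numbers for stronger inhibition. Compound 1, `Cc1cc(N2CCN(C(=O)Nc3ccc(OC(F)(F)F)cc3)CC2)nnc1Cl`, gives > 10000 nM in this assay, which is a limit of the assay rather than a number. Compound 2, `Cc1cnnc(N2CCN(C(=O)Nc3ccc(OC(F)(F)F)cc3)CC2)c1`, gives > 10000 nM, again a limit. Going by the values given here, the single change between these two, a step that the two limits leave unreadable from compound 1 to compound 2, therefore cannot be read in size. Compound 3, `CC(C)(C)c1ccc(NC(=O)N2CCN(c3nncc4ccccc34)CC2)cc1`, gives > 10000 nM, also a limit. Among the compounds with values here, compound 3 thus stands exactly where every compound tested so far stands, namely at the limit of > 10000 nM in this assay, at which 3 of the 3 values shown sit.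

Compound 4, `O=C(Nc1ccc(OC(F)(F)F)cc1)N1CCN(c2nncc3ccccc23)CC1`, differs from compound 3 in one place: trifluoromethoxy in place of tert-butyl on an aromatic carbon. Within the data shown here, no measured step bears on this change directly, since the only measured step, between compound 1 and compound 2, is unreadable, and the group that enters is the very group compound 1 and compound 2 already carry while sitting at the limit. Compound 4 is therefore expected to stay at the limit, so the step that the limit leaves unreadable from compound 3 to compound 4 is expected to be none beyond the scatter. For compound 4 the estimate in this assay is 20000 nM, with a range from 5000 nM to 100000 nM.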

Compound 4, half-maximal inhibitory concentration: > 10000 nM
Compound 4 ended at the assay's limit (the forecaster's own chance of this, stated with the estimate: 80%); the middle value is on the limit's open side.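

Compound 4 gives a limit in this assay, not a number, so its steps from compound 1, compound 2 and compound 3 cannot be read in size. All the compounds shown share one position: the limit of > 10000 nM in this assay, at which 4 of the 4 values shown sit.

The compounds shown leave open how trifluoromethoxy and tert-butyl compare once a compound gives a true number in this assay.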